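Dropping the nitrogen methyl from compound 2

The compounds below may be only part of what the source reports. "The series", "measured", "known", "first", "only" and "open" are said of these compounds alone.

Measured so far:
- compound 1 `Cn1c(/C=C/C(=O)c2ccccc2)cc(Br)c1Br`: >= 100000 nM (a limit of the assay, not a number)
- compound 2 `Cn1c(/C=C/C(=O)c2ccc[nH]2)cc(Br)c1Br`: 2110 nM

Both values come from a functional assay on WRL68 cells (Homo sapiens) for cytotoxicity, read by MTT assay, with stated times of 6 h and 48 h; on this read-out lower numbers stand for stronger inhibition and higher numbers for weaker inhibition. Among the compounds with values here, compound 2 holds the only actual number so far. For compound 1 there is only a limit: the limit of >= 100000 nM in this assay, at which 1 of the 2 values shown sits.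

The next compound is compound 3 `O=C(/C=C/c1cc(Br)c(Br)[nH]1)c1ccc[nH]1`, which differs from compound 2 in one place: hydrogen in place of methyl on an aromatic nitrogen. In words, this is hydrogen in place of methyl on an aromatic nitrogen.

Within the data shown here, the single measured step, an at least 47-fold lower number from compound 1 to compound 2 (1.67 log units; beyond the scatter), is large and beyond the scatter. It concerns a different place, however, with 1H-pyrrol-2-yl in place of phenyl on a carbonyl carbon. Among the measured compounds shown here, no measured step touches the aromatic nitrogen, so its size does not carry over. The expectation therefore starts from compound 2 at 2110 nM, with no shift beyond the scatter in this assay and no firm direction. The expected change is a 1.2-fold higher number from compound 2 to compound 3 (0.07 log units; within the scatter). Compound 3 is estimated at 2500 nM, with an expected range from 700 nM to 10000 nM.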

Compound 3, half-maximal inhibitory concentration: >= 100000 nM
Compound 3: no number, only a limit; the forecaster's own chance of this, stated with the estimate: 5%; middle value at least 40-fold (1.60 log units) from the limit.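

In this assay, the aromatic nitrogen is a position where a single small change counts: hydrogen in place of methyl gives an at least 47-fold higher number from compound 2 to compound 3 (1.67 log units; beyond the scatter). Compound 3 gives >= 100000 nM, which is a limit of the assay and not a number. Compound 2 therefore remains the only compound with a number, and a single change in either of two places, the aromatic nitrogen or the group on the carbonyl carbon, leads to that same limit: the limit of >= 100000 nM in this assay, at which 2 of the 3 values shown sit.

The compounds shown do not tell whether methyl is specifically needed on this nitrogen or whether an ethyl group, a longer chain or a benzyl group would also keep a measurable value. Hydrogen on the aromatic nitrogen together with phenyl on the carbonyl carbon also lies outside the compounds shown, so it stays open whether the two places act independently of each other.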